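Aryl substituent change within the hydrazone series

The source may hold more compounds than are shown below. What is called first, only, known or untested is meant among the compounds shown, and "the series" means these compounds.

Compound 3 `CC1CC/C(=N\Nc2ccc(Br)cc2)c2ncc(C(=O)O)c(=O)n21` stands second highest of the three numbers in a functional assay (mast cells) for inhibition, with Rattus norvegicus as the target (a higher number here means that more compound is needed for the effect, a lower number that less compound is needed), where compound 3 gives 2000 nM. Its nearest neighbour is compound 2 `CC1CC/C(=N\Nc2ccccc2F)c2ncc(C(=O)O)c(=O)n21`, which in this assay gives 1200 nM; the furthest is compound 1 `CC1C/C(=N\Nc2ccccc2)c2ncc(C(=O)O)c(=O)n2C1`, which in this assay gives 13000 nM. Within the data shown here, the one single-point step known, a 1.7-fold higher number from compound 2 to compound 3 (0.22 log units; within the scatter), also swaps the group on the aryl ring and stays within the scatter. Compound 4 `CCCCc1ccc(N/N=C2\CCC(C)n3c2ncc(C(=O)O)c3=O)cc1` differs from compound 3 by butyl in place of bromo on an aromatic carbon. Among the measured compounds shown here, only the step from compound 2 to compound 3 bears on this change, and it stayed within the scatter, so no step beyond the scatter is expected here, no change at the digits printed from compound 3 to compound 4 (within the scatter). Compound 4 is therefore estimated at 2000 nM, within 700 nM to 6000 nM.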

Compound 4, half-maximal effective concentration: 1700 nM
Beside the measured number, compound 4's estimate is 1.2-fold (0.07 log units) above it, within the range that was stated.
By their numbers in this assay, from the lowest: compounds 2, 4 and 3 (each within the scatter of the next); then compound 1.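

Within this assay, the step of a 1.2-fold lower number from compound 3 to compound 4 (0.07 log units; within the scatter) shows that, on this aromatic carbon para to a large group, butyl can stand in place of bromo with the number staying within the scatter. The earlier step changed the 2-fluorophenyl for the 4-bromophenyl, whereas this one keeps the place fixed and changes only the group, a larger chain replacing a single bromine atom. No measurement accompanies this result to explain it. Open at this carbon are an amine, a carboxylic acid and a longer chain such as octyl.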